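The compounds below may be only part of what the source reports. "The series", "measured", "known", "first", "only" and "open" are said of these compounds alone.

Measured so far:
compound 1, `O=S1(=O)N=C(NCc2ccccc2)Nc2ncccc21` — 21.9 uM
compound 2, `C[C@@H](NC1=NS(=O)(=O)c2cccnc2N1)c1ccccc1` — 9.9 uM
compound 3, `CCC(C)NC1=NS(=O)(=O)c2cc(Cl)cnc2N1` — 20 uM

All three were tested in a functional assay (aorta) with Rattus norvegicus as the target; on this read-out lower numbers stand for an effect already at smaller amounts and higher numbers for an effect only at larger amounts of compound. Compound 1 and compound 2 share a core and differ in one place: methyl in place of hydrogen on a saturated chain carbon bound to an amine nitrogen and an aromatic carbon. That change gave a 2.2-fold lower number from compound 1 to compound 2 (0.34 log units; beyond the scatter). Compound 3 carries a different core; how its core differs from that of compound 1 is not broken down here. In this assay compound 3 gives 20 uM, which sits within the usual scatter of the number for compound 1, so no order between those two can be read.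

Compound 4, `CC(C)C(C)NC1=NS(=O)(=O)c2cc(Cl)cnc2N1`, is not yet measured. It differs from compound 3 by methyl in place of hydrogen on a saturated chain carbon bound to two saturated chain carbons. Within the data shown here, this is the same kind of change as the one from compound 1 to compound 2, but not the same: there the methyl entered on a saturated chain carbon bound to an amine nitrogen and an aromatic carbon, here it enters on a saturated chain carbon bound to two saturated chain carbons. Among the measured compounds shown here, because the one measured example of such a change gave a 2.2-fold lower number from compound 1 to compound 2 (0.34 log units; beyond the scatter), a step of similar size is expected here, a 1.7-fold lower number from compound 3 to compound 4 (0.22 log units; within the scatter), though the different place and the different core leave it uncertain. Compound 4 is therefore expected to give about 12 uM in this assay, most likely between 5 uM and 35 uM.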

Compound 4, concentration for half-maximal effect: 10.6 uM
Compound 4: middle estimate off by 1.1-fold (0.05 log units), on the high side; the measured number falls inside the stated range.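

In this assay, the added methyl on a saturated chain carbon bound to two saturated chain carbons gave a 1.9-fold lower number from compound 3 to compound 4 (0.28 log units; within the scatter), so this step alone cannot be told apart from no change. Set beside the earlier step, however, it agrees in direction and in size: the same change on two cores in this assay, a 2.2-fold lower number (0.34 log units; beyond the scatter) from compound 1 to compound 2 and a 1.9-fold lower number (0.28 log units; within the scatter) from compound 3 to compound 4, 1.2-fold (0.07 log units) apart, within the scatter of two such steps This suggests that a methyl added to the chain carbon that carries the amine nitrogen's substituent can be carried from one core to the other with a similar result, but two pairs make no rule, and the methyl does not enter at the same kind of carbon in the two pairs, so the comparison mixes a change of core with a change of place.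

On these data alone, it remains open whether a step of this size would also appear on a third core. The compounds shown also leave open what a hydroxyl, an amine or a longer chain such as hexyl would do in place of this methyl.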